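Shortening the hydroxyalkyl carbonate tail: cytotoxicity in MT4 cells

This account rests on a few compounds, and the source may have more. Where it says the series, first, only, none or still open, it means among the compounds named here.

Compound 1, `Cc1cn(C2CC(N=[N+]=[N-])C(COC(=O)OCCCCCCO)O2)c(=O)[nH]c1=O`: in a functional assay on MT4 cells (Homo sapiens) for cytotoxicity (a higher number here means that more compound is tolerated, a lower number that less compound is tolerated), compound 1 gives > 50000 nM, which is a limit of the assay.
Compound 2, `Cc1cn(C2CC(N=[N+]=[N-])C(COC(=O)CCCC(=O)O)O2)c(=O)[nH]c1=O`: in this assay compound 2 gives > 50000 nM, again a limit.
Compound 3, `Cc1cn(C2CC(N=[N+]=[N-])C(COC(=O)OCCCCCO)O2)c(=O)[nH]c1=O`: in this assay compound 3 gives > 50000 nM, also a limit.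

Compound 3 therefore stands at a limit, as do the two other values, all of them sitting at the limit of > 50000 nM in this assay, at which 3 of the 3 values shown sit. The measured steps are accordingly unreadable: a step that the two limits leave unreadable from compound 1 to compound 2, a step that the two limits leave unreadable from compound 1 to compound 3 and a step that the two limits leave unreadable from compound 2 to compound 3.

Compound 4 is `Cc1cn(C2CC(N=[N+]=[N-])C(COC(=O)OCCCO)O2)c(=O)[nH]c1=O`. It differs from compound 3 in that (hydroxy in place of 2-hydroxyethyl on a saturated chain carbon, three bonds along the chain from an oxygen next to a carbonyl group). Among the compounds with values here, the closest precedent is the chain shortening in the step from compound 1 to compound 3, which was unreadable because both ends sit at the limit of > 50000 nM in this assay, at which 3 of the 3 values shown sit. Within the data shown here, with every value at that limit, no step of any size can be read, and the expected outcome of the step from compound 3 to compound 4 is likewise a limit, a step that the limit leaves unreadable from compound 3 to compound 4. Compound 4 is estimated at 80000 nM, with a range from 30000 nM to 300000 nM, most likely reported again only as a limit.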

Compound 4, half-maximal cytotoxic concentration: > 50000 nM
Compound 4: only a limit was reported (the forecaster's own chance of this, stated with the estimate: 85%); the middle value is on the limit's open side.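

In this assay compound 4 gives > 50000 nM, which is a limit. No new step can be read from compound 4 to compound 1, compound 2 or compound 3: the limit of > 50000 nM in this assay, at which 4 of the 4 values shown sit.

The compounds shown leave open at what concentration any of them becomes cytotoxic, and whether tail length affects that concentration.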